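Hydroxymethyl in place of chloro: a low starting point

The source may hold more compounds than are shown below. What is called first, only, known or untested is meant among the compounds shown, and "the series" means these compounds.

Going by the values given here, in a functional assay on HepG2 cells (Homo sapiens) for inhibition, read by MTT assay, with a stated time of 72 h, tested at 30 uM (on this read-out lower numbers stand for less inhibition of growth and higher numbers for more inhibition of growth at the one concentration tested), compound 2 (`C=CCc1ccc(OCc2cn(-c3ccccc3Cl)nn2)c(O)c1`) gives 2.5%, the lower of the two numbers so far. Compound 1 (`C=CCc1cc(O)c(O)c(CN2CCC(C)CC2)c1`) gives 57.6%, and the gap between the two compounds lies beyond the scatter. Compound 3 (`C=CCc1ccc(OCc2cn(-c3ccccc3CO)nn2)c(O)c1`) has hydroxymethyl in place of chloro on an aromatic carbon, ortho to a large group: hydroxymethyl in place of chloro on an aromatic carbon. Among the compounds with values here, no measured pair shows this change, and compound 1 differs too widely to guide it. A small upward step, within the scatter, is expected: a number 5.5 percentage points higher from compound 2 to compound 3 (within the scatter). For compound 3 the estimated value is 8%, with an expected range of 0% to 25%.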

Compound 3, percent growth inhibition at one concentration: 4.2%
Beside the measured number, compound 3's estimate is 3.8 percentage points above it; measured number inside the range.
By their numbers in this assay, from the lowest: compounds 2 and 3 (each within the scatter of the next); then compound 1.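

In this assay, hydroxymethyl in place of chloro on an aromatic carbon, ortho to a large group, gives a number 1.7 percentage points higher from compound 2 to compound 3 (within the scatter) and does not separate the two compounds. At this position, the exchange of 2-chlorophenyl for 2-(hydroxymethyl)phenyl, which brings in a hydrogen-bond donor and a hydrogen-bond acceptor, leaves growth inhibition low in both compounds. Still open, from the compounds shown here alone, is whether an amine or a carboxylic acid at this aromatic carbon would read differently. No available data bear on the reason for this result.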